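A few compounds are considered here, and "the series" means these few. Any claim that something is new, unique, unknown or untested is made for them only; others in the source may bear on it.

Within the data shown here, compound 1 `CN1CCN(c2nc(-c3ccc(Cl)c(Cl)c3)nc3[nH]cnc23)CC1` is one of three compounds measured so far in an assay on cells for displacement of a labelled ligand from adenosine receptor A1 (Homo sapiens), read by scintillation counting and radioligand binding, with a stated time of 60 min, tested at 10 uM; a higher number here means more inhibition at the concentration tested (going by the name of the read-out), a lower number less inhibition. For compound 1 the assay reports > 80%, which is a limit rather than a number. Compound 3 `CN1CCN(c2nc(-c3ccccc3O)nc3c2ncn3C)CC1` likewise sits at a limit, with > 80%. Compound 2 `Cn1cnc2c(N3CCCCC3)nc(-c3cccc(O)c3O)nc21` is the only one of the three for which a number is reported: in this assay compound 2 gives 17.2%. Thus (the limit of > 80% in this assay, at which 2 of the 3 values shown sit), and compound 2 stands apart as the sole numerical value.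

Compound 4 `Cn1cnc2c(N3CCCCC3)nc(-c3cccc(O)c3)nc21` has not been measured. It differs from compound 2 in one place, (hydrogen in place of hydroxy on an aromatic carbon), a 2,3-dihydroxyphenyl becoming a 3-hydroxyphenyl. Among the measured compounds shown here, no measured pair shows this change, so its effect cannot be read from the data directly. Compound 3 also carries a hydroxy on its phenyl and reaches > 80%, but that is a limit, and compound 3 differs from compound 2 elsewhere as well, so it offers only loose guidance. The expected a number 17.8 percentage points higher from compound 2 to compound 4 (beyond the scatter) is an increase somewhat beyond the scatter. Compound 4 is estimated to give 35%, within 10% to 70%.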

Compound 4, a percentage reported as inhibition, at one concentration (the size of the read-out at that concentration, not a potency): 78.5%
For compound 4 the middle estimate is 43.5 percentage points below the measured one; measured number above the stated range.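

In this assay, the hydroxy on the aromatic carbon ortho to a hydroxy group and ortho to a large group turns out to matter greatly: with hydrogen in its place, the read-out gives a number 61.3 percentage points higher from compound 2 to compound 4 (beyond the scatter). Among these compounds, this is the first step between measured compounds that differ in one place, so it isolates an effect that the earlier compounds could not separate from their other differences. The compounds shown give no reason for the size of this step.

From the compounds shown here alone, it remains open whether a methoxy, a fluorine or an amine at this position would give a similarly high number or one closer to that of compound 2. Going by these compounds, it is also open whether the remaining hydroxy of the 3-hydroxyphenyl contributes anything, which only an unsubstituted phenyl could show.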